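Compound 3: methoxymethyl on the amide carbonyl

This account rests on a few compounds, and the source may have more. Where it says the series, first, only, none or still open, it means among the compounds named here.

In a functional assay on A549 cells (Homo sapiens) for antiproliferative activity, read by sulforhodamine B assay, with a stated time of 3 days (on this read-out lower numbers stand for stronger inhibition of growth and higher numbers for weaker inhibition of growth), compound 1 (`O=C(Nc1cccc(Nc2ncc(F)c(Nc3ccc(F)cc3)n2)c1)c1cnccn1`) gives 10300 nM as a measured number. Compound 2 (`CN(C)c1ccc(C(=O)Nc2cccc(Nc3ncc(F)c(Nc4ccc(F)cc4)n3)c2)cc1`) reads > 10000 nM and this is a limit of the assay, not a number. Going by the values given here, the one measured step bearing on the next change is a step that the limit leaves unreadable from compound 1 to compound 2 with 4-(dimethylamino)phenyl in place of pyrazin-2-yl on a carbonyl carbon, and it gives no size to carry forward. Compound 3 (`COCC(=O)Nc1cccc(Nc2ncc(F)c(Nc3ccc(F)cc3)n2)c1`) keeps the shared core and has methoxymethyl in place of 4-(dimethylamino)phenyl on a carbonyl carbon, counted as methoxymethyl in place of 4-(dimethylamino)phenyl on a carbonyl carbon for the whole exchange. Among the compounds with values here, no direction can be drawn from the measured steps, so the only numeric anchor is compound 1 at 10300 nM within this small series. The estimated change is an at least 1.1-fold lower number from compound 2 to compound 3 (0.04 log units; that floor lies within the scatter) and it is expected to stay modest in this assay with no firm direction. For compound 3 the expected value is 9000 nM with an estimated range from 3500 nM to 20000 nM and a result that is only a limit of the assay remains quite possible.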

Compound 3, concentration for 50% growth inhibition: 2050 nM
Beside the measured number, compound 3's estimate is 4.4-fold (0.64 log units) above it; the measured number lies below the stated range.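

In this assay, going by these compounds alone, methoxymethyl in place of pyrazin-2-yl on a carbonyl carbon gives a 5.0-fold lower number from compound 1 to compound 3 (0.70 log units; beyond the scatter), the first step at this place that has a readable size, and it shows that a group with no ring can be carried there without loss of growth inhibition. The whole exchange of 4-(dimethylamino)phenyl for methoxymethyl at the same place gives an at least 4.8-fold lower number from compound 2 to compound 3 (0.68 log units; beyond the scatter), so both ring-bearing groups shown lie on the weaker side of methoxymethyl, with no compound here going against that. Compound 2 holds only a limit of the assay, which makes that second step a floor and not a size: the limit of > 10000 nM in this assay, at which 1 of the 3 values shown sits.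

The compounds shown do not separate the loss of the ring from the drop in group size or from the entry of the ether oxygen, as all three change together in compound 3. Still open, as far as these compounds go, is how this assay would read for a plain ethyl group, a longer ether chain, a hydroxymethyl group or an aliphatic amine on the same carbonyl carbon, and whether any of these would bring the number further down.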